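Compound 3 to compound 4: one added hydroxy

The source may hold more compounds than are shown below. What is called first, only, known or untested is meant among the compounds shown, and "the series" means these compounds.

- compound 1 `COc1ccc(-c2cc(OC)c3ccccc3n2)cc1O` gives "not active" (no number reported)
- compound 2 `COc1cc(-c2cc(OC)c3ccccc3n2)ccc1O` gives 500 nM
- compound 3 `COc1cc(-c2cc(=O)c3cc(C)c(C)cc3o2)ccc1OCc1ccccc1` gives 500 nM

For the measured compounds named here, all three readings come from a functional assay on HT-22 cells (Mus musculus), read by MTT assay, with a stated time of 24 h (on this read-out higher numbers stand for an effect only at larger amounts of compound and lower numbers for an effect already at smaller amounts), and no pair among them differs in one place only. Level with compound 2, compound 3 stands at 500 nM within the scatter, while compound 1 yields no number at all.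

The next structure is compound 4 `COc1cc(-c2oc3cc(C)c(C)cc3c(=O)c2O)ccc1OCc1ccccc1` and the change from compound 3 is hydroxy in place of hydrogen on an aromatic carbon with hydroxy in place of hydrogen on an aromatic carbon of the six-membered aromatic ring with 1 oxygen. Going by the values given here, no measured pair shows what such a change does here, so no direction is favoured. The expected step in this assay is a 1.3-fold lower number from compound 3 to compound 4 (0.10 log units; within the scatter) and it is not expected to go beyond the scatter. Among the compounds with values here, only three compounds have been read, and one of those gave no number, so the range stays wide. Compound 4 is estimated at 400 nM with a range from 100 nM to 1500 nM in this working estimate.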

Compound 4, half-maximal effective concentration: 170 nM
The estimate for compound 4 lay 2.4-fold (0.37 log units) above the measured number; low and high end bracket the measured number.
By their numbers in this assay, from the lowest: compound 4; then compounds 2 and 3 (each within the scatter of the next).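

In this assay, hydroxy in place of hydrogen on an aromatic carbon of the six-membered aromatic ring with 1 oxygen, two atoms from the ring oxygen, gives a 2.9-fold lower number from compound 3 to compound 4 (0.47 log units; beyond the scatter). For the compounds shown here, this is the first pair that differs in one place only, so this position now has a measured direction: the added hydroxy lowers the number, though this rests on a single pair. No supporting measurement bears on why the number falls at this position.

Open, as far as these compounds go, is whether the lower number belongs to hydroxy itself or would also follow from methoxy or an amine on the same carbon. Also open, from the compounds shown here alone, is whether the step carries over to the core of compound 2, which differs from compound 3 in more than one place.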